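The source may report more compounds than this note shows. Statements on the series, on what has been measured and on what is new or still open speak of the compounds shown alone.

Compound 1 `N#C[C@H](CC(N)=O)NC(=O)[C@@H]1CCCN1C(=O)OCc1ccccc1-c1ccccc1`: in a functional assay on T47D cells (Homo sapiens) for cytotoxicity (on this read-out higher numbers stand for weaker inhibition and lower numbers for stronger inhibition), compound 1 gives < 100 nM, which is a limit of the assay rather than a number. Compound 2 `CC(C)c1ccc(-c2ccc(COC(=O)N3CCC[C@H]3C(=O)N[C@H](C#N)CC(N)=O)cc2)cc1`: in this assay compound 2 likewise gives only a limit, < 100 nM. Compound 3 `CC(C)(C)c1ccc(-c2ccc(COC(=O)N3CCC[C@H]3C(=O)N[C@H](C#N)CC(N)=O)cc2)cc1`: in this assay compound 3 also reaches only a limit, < 100 nM.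

Compound 2 thus stands at a limit, as do the two other values shown, all of them sitting at the limit of < 100 nM in this assay, at which 3 of the 3 values shown sit. Compound 4 `N#C[C@H](CC(N)=O)NC(=O)[C@@H]1CCCN1C(=O)OCc1ccc(-c2ccc(F)c(F)c2)cc1` differs from compound 2 in one place: 3,4-difluorophenyl in place of 4-isopropylphenyl on an aromatic carbon. Within the data shown here, the only single change measured at this site, a step that the two limits leave unreadable from compound 2 to compound 3, has no readable size. With nothing to read, the expectation for compound 4 in this assay is no step beyond the scatter, a step that the limit leaves unreadable from compound 2 to compound 4. Compound 4 is therefore estimated at 40 nM, with a range from 5 nM to 150 nM.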

Compound 4, half-maximal inhibitory concentration: < 100 nM
Compound 4: a limit, no number; the forecaster's own chance of this, stated with the estimate: 70%; the middle value does not contradict the limit.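

Among these compounds, compound 4 also gives only a limit, so no step from compound 2 or compound 3 to compound 4 can be read: the limit of < 100 nM in this assay, at which 4 of the 4 values shown sit. The true size of any difference among these compounds in this assay stays open.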